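Propoxy for propyl on the core: expected whole-animal dose

The source may hold more compounds than are shown below. What is called first, only, known or untested is meant among the compounds shown, and "the series" means these compounds.

Compound 3 `CCCc1nc(N)c2nc(O)n(Cc3ccccc3)c2n1` gives 3 mg/kg in a functional assay on the whole organism for activation, with Mus musculus as the target (a higher number here means that more compound is needed for the effect, a lower number that less compound is needed), the highest number among the three measured compounds. Compound 1 `CCCSc1nc(N)c2nc(O)n(Cc3ccccc3)c2n1` gives 0.1 mg/kg, and compound 2 `CCCCSc1nc(N)c2nc(O)n(Cc3ccccc3)c2n1` gives 0.3 mg/kg. Compound 4 `CCCOc1nc(N)c2nc(O)n(Cc3ccccc3)c2n1` is not yet measured; it differs from compound 3 by propoxy in place of propyl on an aromatic carbon.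

The measured step that bears most directly on this change is a 30-fold higher number from compound 1 to compound 3 (1.48 log units; beyond the scatter), where a sulfur-linked propyl chain on that aromatic carbon was exchanged for a directly attached propyl. The step of a 10-fold higher number from compound 2 to compound 3 (1.00 log units; beyond the scatter) points the same way, and a 3.0-fold higher number from compound 1 to compound 2 (0.48 log units; beyond the scatter) shows that lengthening the chain on the sulfur side costs a modest amount. For the measured compounds named here, no measured compound carries an oxygen-linked chain at that position, so how closely propoxy tracks propylsulfanyl is open.

Restoring a heteroatom-linked three-carbon chain is therefore expected to lower the number relative to compound 3, plausibly by less than the full a 30-fold higher number from compound 1 to compound 3 (1.48 log units; beyond the scatter). Compound 4 is expected to give 0.5 mg/kg in this assay, with a range of 0.1 mg/kg to 3 mg/kg. That expectation corresponds to a 6.0-fold lower number from compound 3 to compound 4 (0.78 log units; beyond the scatter).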

Compound 4, minimum effective dose: 0.3 mg/kg
Estimate against measurement, compound 4: 1.7-fold (0.22 log units) above; the measured number falls inside the stated range.
By their numbers in this assay, from the lowest: compound 1; then compounds 2 and 4 (each within the scatter of the next); then compound 3.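

In this assay, the change to propoxy on the aromatic carbon between two ring nitrogen atoms gives a 10-fold lower number from compound 3 to compound 4 (1.00 log units; beyond the scatter), so the gain over a directly attached propyl does not require a sulfur-linked chain. The two linked three-carbon chains still differ, with a 3.0-fold higher number from compound 1 to compound 4 (0.48 log units; beyond the scatter) for propoxy in place of propylsulfanyl, while the exchange for butylsulfanyl gives no change at the digits printed from compound 2 to compound 4 (within the scatter) and leaves the two compounds level within the scatter. Nothing available explains these differences.

Still open, on these data alone, is whether butoxy would follow the step seen on the sulfur side, a 3.0-fold higher number from compound 1 to compound 2 (0.48 log units; beyond the scatter), or behave differently. Also open, as far as these compounds go, is where a propylamino chain on the same carbon would fall relative to propoxy and propylsulfanyl.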